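Shifting a Trifluoromethyl Group Around a Shared Core

This account rests on a few compounds, and the source may have more. Where it says the series, first, only, none or still open, it means among the compounds named here.

Compound 1 `Oc1ccccc1-c1cc(-c2cccc(C(F)(F)F)c2)cc(-c2ccccc2O)n1` and compound 2 `Oc1ccccc1-c1cc(-c2ccc(C(F)(F)F)cc2)cc(-c2ccccc2O)n1` share a core carrying two 2-hydroxyphenyl groups. In a functional assay on T47D cells (Homo sapiens) for inhibition (on this read-out lower numbers stand for stronger inhibition and higher numbers for weaker inhibition), compound 1 gives > 50000 nM, which is a limit of the assay rather than a number. Compound 2 likewise gives > 50000 nM, again a limit. The change between the two, (4-(trifluoromethyl)phenyl in place of 3-(trifluoromethyl)phenyl on an aromatic carbon), therefore yields a step that the two limits leave unreadable from compound 1 to compound 2.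

Compound 3 `Oc1ccc(-c2cc(-c3cccc(C(F)(F)F)c3)cc(-c3cccc(O)c3)n2)cc1` carries a 3-hydroxyphenyl group and a 4-hydroxyphenyl group instead; how its core differs from that of compound 1 is not broken down here. In this assay, among the compounds with values here, compound 3 gives 2630 nM, the only true number among the three measurements, since (the limit of > 50000 nM in this assay, at which 2 of the 3 values shown sit).

Compound 4 `Oc1ccc(-c2cc(-c3ccc(C(F)(F)F)cc3)cc(-c3cccc(O)c3)n2)cc1` has not been measured. It differs from compound 3 by 4-(trifluoromethyl)phenyl in place of 3-(trifluoromethyl)phenyl on an aromatic carbon. Within the data shown here, this is the same kind of change as the one between compound 1 and compound 2, but the surroundings differ: here the place is meta to a 3-hydroxyphenyl group and meta to a 4-hydroxyphenyl group, whereas there it was meta to two 2-hydroxyphenyl groups. With the earlier step unreadable, a step of a 1.1-fold lower number from compound 3 to compound 4 (0.02 log units; within the scatter) is expected, meaning little change. Compound 4 is estimated at 2500 nM, likely between 900 nM and 8000 nM.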

Compound 4, half-maximal inhibitory concentration: 2870 nM
Beside the measured number, compound 4's estimate is 1.1-fold (0.06 log units) below it; low and high end bracket the measured number.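

In this assay, placing 4-(trifluoromethyl)phenyl in place of 3-(trifluoromethyl)phenyl gives a 1.1-fold higher number from compound 3 to compound 4 (0.04 log units; within the scatter), so on this core the two groups cannot be told apart. The matching step on the core of compound 1 cannot be read, which means the change cannot be compared across the two cores, and compound 1 and compound 2 offer no test of whether it carries over: the limit of > 50000 nM in this assay, at which 2 of the 4 values shown sit. The result therefore shows that the swap is tolerated on one core only, and it supports no rule for other cores in this series.

No pair shown differs in just one hydroxyphenyl group, so what each of these groups contributes on its own stays open. Also open, on these data alone, is how this core would respond if an amine, a carboxylic acid or a longer chain stood in place of the trifluoromethyl group.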